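Terminal chain groups and growth inhibition in the series

The compounds below may be only part of what the source reports. "The series", "measured", "known", "first", "only" and "open" are said of these compounds alone.

Measured in a functional assay on SK-MEL-5 cells (Homo sapiens) for antiproliferative activity; a lower number here means a stronger inhibitor of growth, a higher number a weaker inhibitor of growth:
- compound 1 `COCCCCCCCCCCCCCCC/C=C1\CC(CO)(COC(=O)C(C)(C)C)OC1=O`: 1.75 ug/mL
- compound 2 `COCCCCCCCCCCC/C=C1\CC(CO)(COC(=O)C(C)(C)C)OC1=O`: 2.81 ug/mL
- compound 3 `CC(C)(C)C(=O)OCC1(CO)C/C(=C\CCCCCCCCCCCO)C(=O)O1`: 5.81 ug/mL

Compound 3 has the highest number of the three, beyond the scatter from both others. Compound 4 `CC(=O)OCCCCCCCCCCCCCCC/C=C1\CC(CO)(COC(=O)C(C)(C)C)OC1=O` differs from it as follows: 4-acetoxybutyl in place of hydroxy on a saturated chain carbon, ten or more bonds along the chain from a double-bonded chain carbon. The closest measured change is a 3.3-fold higher number from compound 1 to compound 3 (0.52 log units; beyond the scatter), with hydroxy replacing 4-methoxybutyl at the same place. The change here runs the opposite way. The other measured steps are a 2.1-fold higher number from compound 2 to compound 3 (0.32 log units; beyond the scatter) and a 1.6-fold higher number from compound 1 to compound 2 (0.21 log units; within the scatter). Within the data shown here, no measured compound carries 4-acetoxybutyl, so the size remains uncertain. A lower number is expected in this assay, with an expected 2.4-fold lower number from compound 3 to compound 4 (0.38 log units; beyond the scatter). The estimate for compound 4 is 2.4 ug/mL, with an expected range of 1.2 ug/mL to 4.8 ug/mL.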

Compound 4, concentration for 50% growth inhibition: 5.62 ug/mL
Compound 4: middle estimate off by 2.3-fold (0.37 log units), on the low side; the measured number lies above the stated range.
By their numbers in this assay, from the lowest: compounds 1, 2, 4 and 3 (each within the scatter of the next, the first and the last beyond it).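

Replacing hydroxy with 4-acetoxybutyl at this chain end leaves the number unresolved (a 1.0-fold lower number from compound 3 to compound 4 (0.01 log units; within the scatter)), so the longer chain with an acetyl end does not separate from the shorter hydroxy chain. At the same chain length, acetyl in place of methyl on the terminal oxygen does register (a 3.2-fold higher number from compound 1 to compound 4 (0.51 log units; beyond the scatter)), so the end group counts here, not chain length alone. Against the shorter methoxy chain, the acetyl compound stays within the scatter (a 2.0-fold higher number from compound 2 to compound 4 (0.30 log units; within the scatter)).

As far as these compounds go, whether an amine or a carboxylic acid at this chain end would shift the number remains open. Nothing shown accounts for these steps.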